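The source may report more compounds than this note shows. Statements on the series, on what has been measured and on what is new or still open speak of the compounds shown alone.

Measured compounds in this series:

Compound 1 `N=C(N)NCCCC[C@@H](NS(=O)(=O)Cc1ccccc1)C(=O)N1CCC[C@H]1C(=O)NCc1ccc(C(=N)N)cc1` gives 13 nM in an assay on isolated protein for inhibition of transmembrane protease serine 11D (Homo sapiens), read by fluorescence; on this read-out lower numbers stand for stronger inhibition and higher numbers for weaker inhibition.
Compound 2 `N=C(N)c1ccc(CNC(=O)[C@@H]2CCCN2C(=O)[C@@H](CC(=O)O)NS(=O)(=O)Cc2ccccc2)cc1` gives 1430 nM in this assay.

Compound 2 stands highest of the two numbers; its nearest neighbour is compound 1, and the step of a 110-fold higher number from compound 1 to compound 2 (2.04 log units; beyond the scatter) is large. Compound 3 `CC(C)N1CCN(C(=O)C[C@@H](NS(=O)(=O)Cc2ccccc2)C(=O)N2CCC[C@H]2C(=O)NCc2ccc(C(=N)N)cc2)CC1` is not yet measured. It differs from compound 2 by 4-isopropylpiperazin-1-yl in place of hydroxy on a carbonyl carbon. Among the measured compounds shown here, the only measured step that bears on this position is the one from compound 1 to compound 2, where a group holding three nitrogen atoms and no ring was exchanged for a group holding two oxygen atoms, with a large loss. The change to compound 3 brings back a group holding two nitrogen atoms at the same end of the chain, so part of that loss is expected to be recovered, without reaching compound 1. For compound 3 the expected step is a 5.7-fold lower number from compound 2 to compound 3 (0.76 log units; beyond the scatter), giving an estimate of 250 nM, with a range from 50 nM to 1200 nM.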

Compound 3, inhibition constant: 221 nM
Estimate against measurement, compound 3: 1.1-fold (0.05 log units) above; the range from low to high includes it.
By their numbers in this assay, from the lowest: compound 1; then compound 3; then compound 2.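

In this assay the hydroxy on this carbonyl carbon is not needed for inhibition: with 4-isopropylpiperazin-1-yl in its place there is a 6.5-fold lower number from compound 2 to compound 3 (0.81 log units; beyond the scatter), so this position accepts a much larger group carrying a six-membered non-aromatic ring and no longer carrying a carboxy. The recovery is only partial, as the group of compound 1 still compares with this amide through a 17-fold higher number from compound 1 to compound 3 (1.23 log units; beyond the scatter), and the position therefore separates the three side chains clearly. No measurement shown here accounts for either step.

Open, from the compounds shown here alone, is whether the gain depends on the ring alone or on its second nitrogen and isopropyl, which piperidin-1-yl or morpholine on the same carbonyl carbon would test. Also open, going by these compounds, is whether an open-chain primary amine at this carbonyl carbon comes closer to compound 1.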